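The source may hold more compounds than are shown below. What is called first, only, known or untested is meant among the compounds shown, and "the series" means these compounds.

In a functional assay on MCF7 cells (Homo sapiens) for inhibition, read by MTT assay, with a stated time of 72 h (on this read-out lower numbers stand for stronger inhibition and higher numbers for weaker inhibition), compound 1 `CC(C)c1ccc(-c2nc(SCc3cn(CC(=O)NC(=O)Nc4ccccn4)nn3)nc(Nc3ccccc3)c2C#N)cc1` gives only a limit, > 64000 nM. Compound 2 `COc1ccc(Nc2nc(SCc3cn(CC(=O)NC(=O)Nc4ccccn4)nn3)nc(-c3ccc(C(C)C)cc3)c2C#N)cc1` also gives only a limit in this assay, > 64000 nM. Within the data shown here, the single step between the two, a step that the two limits leave unreadable from compound 1 to compound 2, has no readable size, both ends being limits; the two values show nothing more than that each sits at the limit. Among the measured compounds shown here, the only evidence on the series is the limit of > 64000 nM in this assay, at which 2 of the 2 values shown sit. Compound 2 therefore stands at the limit of this assay, and no order between it and compound 1 can be drawn.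

Compound 3 `CC(C)c1ccc(-c2nc(SCc3cn(CC(=O)NC(=O)Nc4ccccn4)nn3)nc(Nc3ccccc3O)c2C#N)cc1` differs from compound 2 by 2-hydroxyphenyl in place of 4-methoxyphenyl on a nitrogen on an aromatic ring. For the measured compounds named here, no measured step bears on this change; the one step that exists, a step that the two limits leave unreadable from compound 1 to compound 2, gives no size to lean on. No direction can be expected on that basis, and the expectation for compound 3 is that it also remains at the limit in this assay. The estimated step from compound 2 to compound 3, a step that the limit leaves unreadable from compound 2 to compound 3, is expected to be none beyond the scatter. Compound 3 is estimated at 100000 nM with a range from 30000 nM to 400000 nM.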

Compound 3, half-maximal inhibitory concentration: > 64000 nM
Compound 3 gave a limit, no number; the forecaster's own chance of this, stated with the estimate: 85%; the middle value does not contradict the limit.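

In this assay compound 3 gives > 64000 nM, a limit and not a number. Among these compounds, compound 1, compound 2 and compound 3 all stand at limits, so no step among them can be read. The series rests on one observation: the limit of > 64000 nM in this assay, at which 3 of the 3 values shown sit.

Open is what potency any of these compounds has in this assay, and whether any change among them alters it.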